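The source may hold more compounds than are shown below. What is called first, only, known or untested is meant among the compounds shown, and "the series" means these compounds.

Three compounds have so far been measured in a functional assay on KB cells (Homo sapiens) for inhibition, with a stated time of 72 h; on this read-out higher numbers stand for weaker inhibition and lower numbers for stronger inhibition:

Compound 3 `COc1ccc(S(=O)(=O)N2CCc3cccc(-c4ccc(F)c(F)c4)c32)cc1` gives 45 nM.
Compound 1 `COc1ccc(S(=O)(=O)N2CCc3cccc(-c4ccc(F)nc4)c32)cc1` gives 143 nM.
Compound 2 `COc1ccc(S(=O)(=O)N2CCc3cccc(-c4c(F)c(F)c(F)c(F)c4F)c32)cc1` gives 4040 nM.

Compound 3 stands at the lowest number of the three, meaning the strongest inhibition seen here. Its nearest neighbour is compound 1, and the step of a 3.2-fold lower number from compound 1 to compound 3 (0.50 log units; beyond the scatter) shows how much the number fell when one six-membered aromatic group replaced another. Compound 2 lies far away at the weak end, and this gap is well beyond the scatter.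

Compound 4 `COc1ccc(S(=O)(=O)N2CCc3cccc(-c4cccs4)c32)cc1` is the next compound, and it differs from compound 3 in one place: thiophen-2-yl in place of 3,4-difluorophenyl on an aromatic carbon. This is a swap of a six-membered aromatic ring of carbon only for a five-membered aromatic ring with a sulfur atom, at the same place on the shared core.

Within the data shown here, only one measured step bears on the question, a 3.2-fold lower number from compound 1 to compound 3 (0.50 log units; beyond the scatter), and it was modest; it also kept a six-membered ring on both sides. Among the measured compounds shown here, no measured step covers a five-membered ring at this place, so the expectation rests on the observation that modest changes to this group gave modest shifts. A small move toward a higher number, hardly beyond the scatter, is expected for compound 4, which is estimated at 100 nM with a likely range from 30 nM to 400 nM. The expected step is therefore a 2.2-fold higher number from compound 3 to compound 4 (0.35 log units; beyond the scatter).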

Compound 4, half-maximal inhibitory concentration: 215 nM
Beside the measured number, compound 4's estimate is 2.2-fold (0.33 log units) below it; low and high end bracket the measured number.
By their numbers in this assay, from the lowest: compound 3; then compounds 1 and 4 (each within the scatter of the next); then compound 2.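

In this assay, thiophen-2-yl in place of 3,4-difluorophenyl gives a 4.8-fold higher number from compound 3 to compound 4 (0.68 log units; beyond the scatter), a modest loss of inhibition, so this aromatic carbon accepts a five-membered aromatic ring with a sulfur atom, but that ring does not match the best six-membered group seen so far. Set against the other six-membered group, 6-fluoropyridin-3-yl, the same swap gives a 1.5-fold higher number from compound 1 to compound 4 (0.18 log units; within the scatter), which lies within the scatter, so a change in ring size at this place need not shift the number beyond the scatter, and the outcome depends on which groups are compared. Nothing measured here explains why 3,4-difluorophenyl gives the lower number in either comparison.

The compounds shown leave open whether the gap between compound 3 and compound 4 follows the ring itself or the two fluorine atoms it carries, a question that a plain phenyl ring or a fluorinated thiophene could help settle. They also leave open how a group of a different kind, such as an amine or a carboxylic acid on the ring at this place, would behave.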